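Replacing a Branched Amine Chain with Dipropylamino

A few compounds are considered here, and "the series" means these few. Any claim that something is new, unique, unknown or untested is made for them only; others in the source may bear on it.

Of the compounds shown here, two built on one shared core have been measured in an assay on HEK293 cells for inhibition of Steryl-sulfatase (Homo sapiens), tested at 0.1 uM; on this read-out higher numbers stand for a stronger effect at the one concentration tested and lower numbers for a weaker effect. Compound 1 `CN(C)CCN(CCN(C)C)c1cccc(C(=O)N2CCc3ccc(OS(N)(=O)=O)cc3C2)c1` gives 0% in this assay, the lowest of the two numbers recorded. Compound 2 `CN(CCCN1CCCCC1)c1ccc(C(=O)N2CCc3ccc(OS(N)(=O)=O)cc3C2)cc1` gives 17.4%, a number that stands above compound 1 by more than the usual scatter. Compound 3 `CCCN(CCC)c1cccc(C(=O)N2CCc3ccc(OS(N)(=O)=O)cc3C2)c1` has not yet been measured. It differs from compound 1 in a single place: dipropylamino in place of bis(2-(dimethylamino)ethyl)amino on an aromatic carbon. The group that enters is smaller than the group it replaces and lacks the two outer dimethylamino arms. Among the measured compounds shown here, no step between measured compounds is recorded, so the expectation for compound 3 rests only on the two small values of compound 1 and compound 2. The step of a number 6 percentage points higher from compound 1 to compound 3 (within the scatter) is expected to be small, within the scatter or at most a slight rise. Compound 3 is therefore expected to give about 6% in this assay, with a plausible range from 0% to 22%.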

Compound 3, a percentage reported as inhibition, at one concentration (the size of the read-out at that concentration, not a potency): 8.3%
For compound 3 the middle estimate is 2.3 percentage points below the measured one; the range from low to high includes it.
By their numbers in this assay, from the lowest: compounds 1, 3 and 2 (each within the scatter of the next, the first and the last beyond it).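

On an aromatic carbon meta to a large group, putting dipropylamino in place of bis(2-(dimethylamino)ethyl)amino gives, in this assay, a number 8.3 percentage points higher from compound 1 to compound 3 (within the scatter). The group that leaves has 11 heavy atoms and 3 hydrogen-bond acceptors, and the group that enters has 7 and 1, so at this position a change that takes away both outer dimethylamino arms does not carry the read-out beyond the usual scatter. No measurement at hand explains this result.

Each compound was read at a single concentration, so this comparison says nothing about potency. The compounds shown leave open whether a morpholine ring or a carboxylic acid on this same aromatic carbon would give a number beyond the scatter of compound 1.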